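The source may report more compounds than this note shows. Statements on the series, on what has been measured and on what is new or still open speak of the compounds shown alone.

Four related compounds are in view here: compound 1 `C#Cc1cn([C@@H]2O[C@H](CO)[C@@H](O)[C@H]2O)c2ncnc(NC)c12`, compound 2 `Nc1nc(N)c2c(-c3cc4ccccc4o3)cn([C@@H]3O[C@H](CO)[C@@H](O)[C@H]3O)c2n1`, compound 3 `COc1nc(N)nc2c1c(-c1ccoc1)cn2[C@@H]1O[C@H](CO)[C@@H](O)[C@H]1O` and compound 4 `COc1nc(N)nc2c1c(-c1cc3ccccc3o1)cn2[C@@H]1O[C@H](CO)[C@@H](O)[C@H]1O`. Among the compounds with values here, in a functional assay on HL-60 cells (Homo sapiens) for antiproliferative activity, read by XTT assay, with a stated time of 72 h (on this read-out lower numbers stand for stronger inhibition and higher numbers for weaker inhibition), compound 1 gives 9060 nM, the only exact number so far. Compound 3 reads > 20000 nM, which is a limit of the assay and not a number, so compound 3 has no exact place on the scale. Compound 4 differs from compound 3 in one place: 1-benzofuran-2-yl in place of furan-3-yl on an aromatic carbon. In words, 1-benzofuran-2-yl stands in place of furan-3-yl on an aromatic carbon. Within the data shown here, no measured pair here isolates this change, so any forecast is loose. Compound 2 also carries 1-benzofuran-2-yl, and its reading of > 15000 nM is likewise a limit. Among the measured compounds shown here, with that limit as the only guide, the estimated step of a number no higher from compound 3 to compound 4 (the limit leaves the size open) in this assay is expected to stay within the usual scatter, in neither direction, and another limit is a likely report. For compound 4 the estimated value is 20000 nM, with an expected range of 8000 nM to 40000 nM.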

Compound 4, half-maximal inhibitory concentration: > 20000 nM
Compound 4 ended at the assay's limit; the forecaster's own chance of this, stated with the estimate: 65%; the middle value lies on the limit itself.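

Within the data shown here, the readings of compound 2, compound 3 and compound 4 in this assay are all limits of the assay and not numbers, and no step to compound 4 can be read from compound 2 or compound 3. The compounds shown leave open whether 1-benzofuran-2-yl in place of furan-3-yl, or methoxy in place of amino, changes the antiproliferative activity at all.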